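The source may hold more compounds than are shown below. What is called first, only, known or untested is meant among the compounds shown, and "the series" means these compounds.

Measured in a functional assay on A549 cells (Homo sapiens) for antiproliferative activity, read by MTT assay, with a stated time of 48 h; on this read-out higher numbers stand for weaker inhibition and lower numbers for stronger inhibition:
- compound 1 `Cc1ccc(-c2nn(-c3ccccc3)cc2C(Nc2nc3cc(C)c(C)cc3s2)c2c(O)ccc3ccccc23)cc1`: 31200 nM
- compound 2 `Cc1cc2nc(NC(c3cn(-c4ccccc4)nc3-c3ccc([N+](=O)[O-])cc3)c3c(O)ccc4ccccc34)sc2cc1C`: 41900 nM

For the measured compounds named here, compound 2, at 41900 nM, lies within the scatter of compound 1, the only other measured compound, so the two cannot be ranked. Compound 3 `Cc1ccc2nc(NC(c3cn(-c4ccccc4)nc3-c3ccc([N+](=O)[O-])cc3)c3c(O)ccc4ccccc34)sc2c1` carries one change from compound 2: hydrogen in place of methyl on an aromatic carbon, turning 5,6-dimethyl-1,3-benzothiazol-2-yl into 6-methyl-1,3-benzothiazol-2-yl. Going by the values given here, the single measured step, a 1.3-fold higher number from compound 1 to compound 2 (0.13 log units; within the scatter), is a different change, nitro in place of methyl, so it bears only indirectly. No shift beyond the scatter is therefore expected in this assay. The expected step is a 1.1-fold lower number from compound 2 to compound 3 (0.04 log units; within the scatter). The estimate for compound 3 is 38000 nM, with an expected range of 16000 nM to 85000 nM.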

Compound 3, half-maximal inhibitory concentration: 29000 nM
Estimate against measurement, compound 3: 1.3-fold (0.12 log units) above; measured number inside the range.
By their numbers in this assay, from the lowest: compounds 3, 1 and 2 (each within the scatter of the next).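

In this assay, hydrogen in place of methyl on the benzothiazole group gives a 1.4-fold lower number from compound 2 to compound 3 (0.16 log units; within the scatter). For the compounds shown here, the earlier compounds differed only in the nitro and methyl groups on the other side of the molecule, so this is the first sign that 5,6-dimethyl-1,3-benzothiazol-2-yl and 6-methyl-1,3-benzothiazol-2-yl cannot be told apart on this read-out. No measurement at hand gives a reason for this result.

Only hydrogen and methyl are seen at this place. On these data alone, whether a methoxy group, an amine or a longer chain there would move the number beyond the scatter remains open.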